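Ester Size and Half-Life in Phosphate Buffer

The source may report more compounds than this note shows. Statements on the series, on what has been measured and on what is new or still open speak of the compounds shown alone.

For the measured compounds named here, compound 2 `COC(=O)[C@H](O)[C@H]1C(=O)N2C(C(=O)O)=C(C(C)(C)C)O[C@H]12` gives 6.7 h in an ADME assay, in phosphate buffer, at 28 degrees C, at pH 7.0 (on this read-out lower numbers stand for a shorter-lived compound and higher numbers for a longer-lived compound), the lowest of the two numbers measured so far, while compound 1 `C[C@H](O)[C@H]1C(=O)N2C(C(=O)O)=C(C(C)(C)C)O[C@H]12` gives 7.1 h in this assay, and a 1.1-fold lower number from compound 1 to compound 2 (0.03 log units; within the scatter) lies within the scatter. Compound 3 `CC(C)(C)OC(=O)[C@H](O)[C@H]1C(=O)N2C(C(=O)O)=C(C(C)(C)C)O[C@H]12` differs from compound 2 by tert-butyl in place of methyl on an oxygen next to a carbonyl group. Going by the values given here, only one measured step bears on this change, and a 1.1-fold lower number from compound 1 to compound 2 (0.03 log units; within the scatter) was within the scatter, so no step beyond the scatter is expected in this assay. Compound 3 is therefore expected to give 6.5 h, between 3.5 h and 12 h. The expected step is a 1.0-fold lower number from compound 2 to compound 3 (0.01 log units; within the scatter).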

Compound 3, half-life: 10.7 h
Compound 3: middle estimate off by 1.6-fold (0.22 log units), on the low side; the range from low to high includes it.
By their numbers in this assay, from the lowest: compounds 2, 1 and 3 (each within the scatter of the next).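

In this assay, tert-butyl in place of methyl on an oxygen next to a carbonyl group gives a 1.6-fold higher number from compound 2 to compound 3 (0.20 log units; within the scatter), so even this larger group does not carry the ester beyond the scatter. Replacing the methyl of compound 1 with tert-butoxycarbonyl gives a 1.5-fold higher number from compound 1 to compound 3 (0.18 log units; within the scatter), so all three compounds stay within the scatter of one another. Nothing available here accounts for these results. As far as these compounds go, whether a benzyl group or a longer chain on that oxygen, or an amine in place of the ester, would bring a step beyond the scatter remains open.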